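The source may report more compounds than this note shows. Statements on the series, on what has been measured and on what is new or still open speak of the compounds shown alone.

In an ADME assay on a cell-free system (plasma, Mus musculus) for metabolic stability, tested at 1 uM (on this read-out higher numbers stand for a longer-lived compound and lower numbers for a shorter-lived compound), compound 1 (`C=CC(=O)NC1CCN(S(=O)(=O)c2ccc(C(=O)N[C@@H]3C[C@H]3c3ccccc3)cc2)CC1`) gives > 6 h as a limit of the assay, not a number. Compound 2 (`C=CC(=O)NC1CCN(S(=O)(=O)c2ccc(C(=O)N(C)Cc3ccccc3)cc2)CC1`) gives > 6 h as a limit too. The measured picture is thus the limit of > 6 h in this assay, at which 2 of the 2 values shown sit, and nothing finer. Within the data shown here, compound 3 (`C=CC(=O)NC1CCN(S(=O)(=O)c2ccc(C(=O)NCc3cccc4ccccc34)cc2)CC1`) is reached from compound 1 by (naphthalen-1-yl)methyl in place of 2-phenylcyclopropyl on an amide-type nitrogen as the one change: (naphthalen-1-yl)methyl in place of 2-phenylcyclopropyl on an amide-type nitrogen. Among the measured compounds shown here, the one measured step (a step that the two limits leave unreadable from compound 1 to compound 2) gives no size to carry over, so no step beyond the scatter is expected in this assay in either direction. The estimated step is a step that the limit leaves unreadable from compound 1 to compound 3 on that reading. Compound 3 is expected near 7 h with 4 h to 12 h as its estimated range.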

Compound 3, half-life: > 6 h
Compound 3 ended at the assay's limit; the forecaster's own chance of this, stated with the estimate: 85%; the middle value is on the limit's open side.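

No size can be read for the step from compound 1 to compound 3 in this assay, because the results end at a limit of the assay, not a number: the limit of > 6 h in this assay, at which 3 of the 3 values shown sit. The compounds shown leave open how long the half-life of each one really is and whether compound 1, compound 2 and compound 3 differ at all.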